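The compounds below may be only part of what the source reports. "The series", "measured", "known", "first", "only" and "open" are said of these compounds alone.

Of the compounds shown here, two of this set have so far been tested in a functional assay on HCT-116 cells (Homo sapiens) for inhibition, with a stated time of 72 h; on this read-out lower numbers stand for stronger inhibition and higher numbers for weaker inhibition. Compound 1 `NS(=O)(=O)c1ccc(S(=O)(=O)Nc2cccc3c(Cl)c[nH]c23)cn1` gives 290 nM in this assay, and compound 2 `Cc1cncc(S(=O)(=O)Nc2cccc3c(C#N)c[nH]c23)c1` gives 190 nM in this assay. Compound 1 stands at the highest of the two numbers shown, yet its gap to compound 2 lies within the usual scatter, so the two results cannot be separated. For the measured compounds named here, these two structures differ in more than one place, and no single step between them is counted here.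

Compound 3 `CC(C)Nc1ccc(S(=O)(=O)Nc2cccc3c(Cl)c[nH]c23)cn1` remains to be measured. It is derived from compound 1 by one change, in which the sulfamoyl group leaves and an isopropylamino group enters: isopropylamino in place of sulfamoyl on an aromatic carbon. Going by the values given here, no measured pair in this set shows the effect of such a change, so any expectation rests on compound 1 alone. The expected step is therefore small, most likely not beyond the scatter, and its direction is uncertain: a 1.5-fold lower number from compound 1 to compound 3 (0.16 log units; within the scatter). Compound 3 is accordingly estimated to give 200 nM in this assay, with a plausible range from 60 nM to 700 nM.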

Compound 3, half-maximal inhibitory concentration: 1300 nM
Compound 3: the middle estimate sits 6.5-fold (0.81 log units) below what was measured; the measured number lies above the stated range.
By their numbers in this assay, from the lowest: compounds 2 and 1 (each within the scatter of the next); then compound 3.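

In this assay, for the compounds shown here, isopropylamino in place of sulfamoyl gives a 4.5-fold higher number from compound 1 to compound 3 (0.65 log units; beyond the scatter) and so provides the first single-place step in this set, one that lies beyond the scatter and shows that the number responds to the group on this aromatic carbon, next to the ring nitrogen and para to a large group. The two groups are counted with the same number of heavy atoms and of hydrogen-bond donors, so these counts alone do not separate them, although sulfamoyl has more hydrogen-bond acceptors and a different set of atoms. Nothing at hand explains the rise in the number, and this one step gives no mechanism for it.

The compounds shown leave open whether the higher number follows from losing sulfamoyl or from introducing isopropylamino, a question that a plain amine, a methylamino group, a carboxylic acid or a methylsulfonyl group at the same carbon could help to separate. They also do not show whether the same replacement would have a similar effect with the nitrile on the shared core or with other groups elsewhere on the molecule.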